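Estimating the half-life of compound 3

The compounds below may be only part of what the source reports. "The series", "measured", "known", "first", "only" and "open" are said of these compounds alone.

Compound 1 (`N[C@@H](CC(=O)OC[C@H]1O[C@@H](n2cc(F)c(=O)[nH]c2=O)C[C@@H]1O)C(=O)O`), compound 2 (`CC(C)[C@H](N)C(=O)OC[C@H]1O[C@@H](n2cc(F)c(=O)[nH]c2=O)C[C@@H]1O`) and compound 3 (`N[C@@H](CCC(=O)OC[C@H]1O[C@@H](n2cc(F)c(=O)[nH]c2=O)C[C@@H]1O)C(=O)O`) share one core and differ only in the group on a carbonyl carbon. In an ADME assay on tissue (ZR-75-1 cells, Homo sapiens) for pharmacokinetics (on this read-out higher numbers stand for a longer-lived compound and lower numbers for a shorter-lived compound), compound 2 gives 0.273 h while compound 1 gives 0.223 h and these two numbers lie within the usual scatter of each other, so neither can be ranked above the other.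

The move to compound 3 is a single exchange (3-amino-3-carboxypropyl in place of 1-amino-2-methylpropyl on a carbonyl carbon): 3-amino-3-carboxypropyl in place of 1-amino-2-methylpropyl on a carbonyl carbon. Going by the values given here, only one measured step bears on it (a 1.2-fold higher number from compound 1 to compound 2 (0.09 log units; within the scatter)). That step also replaces 1-amino-2-methylpropyl, there with 2-amino-2-carboxyethyl, a group that likewise carries amino and carboxy in its name, and it stays within the scatter. One small step is thin evidence, but it gives no reason to expect a real shift in either direction. The expected step is therefore none beyond the scatter (a 1.1-fold lower number from compound 2 to compound 3 (0.04 log units; within the scatter)). The estimated half-life of compound 3 is 0.25 h (expected range 0.12 h to 0.5 h).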

Compound 3, half-life: 0.205 h
For compound 3 the middle estimate is 1.2-fold (0.09 log units) above the measured one, within the range that was stated.
By their numbers in this assay, from the lowest: compounds 3, 1 and 2 (each within the scatter of the next).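

In this assay, putting 3-amino-3-carboxypropyl in place of 1-amino-2-methylpropyl on the carbonyl carbon gives a 1.3-fold lower number from compound 2 to compound 3 (0.12 log units; within the scatter), so the branched group without a carboxy group and the unbranched one with it cannot be told apart on this read-out. Going by these compounds alone, the new compound also tests chain length for the first time, since compound 1 and compound 3 differ only by the longer chain of compound 3, and that change gives a 1.1-fold lower number from compound 1 to compound 3 (0.04 log units; within the scatter). Across these three compounds, then, neither change at this position shifts the half-life beyond the usual scatter, and no accompanying measurement speaks to why the numbers stay so close.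

Going by these compounds, all three groups carry an amine, so it remains open whether a plain alkyl chain without an amine, or a phenyl ring, would give a half-life in the same range. A chain longer than 3-amino-3-carboxypropyl, or a carboxylic acid on a group with no amine, is also untested by the compounds shown here.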